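This account rests on a few compounds, and the source may have more. Where it says the series, first, only, none or still open, it means among the compounds named here.

Measured compounds:
compound 1, `CC(C)(C)N(NC(=O)c1ccccc1)C(=O)c1ccccc1Cl`: 75.9 nM
compound 2, `CC(C)(C)N(NC(=O)c1ccc(Br)cc1)C(=O)c1ccccc1Cl`: 33.9 nM
compound 3, `Cc1ccc(C(=O)NN(C(=O)c2ccccc2Cl)C(C)(C)C)cc1`: 18.6 nM

All three numbers come from an assay on cells for agonist activity at ecdysone receptor (Bombyx mori), read by a luciferase reporter, with a stated time of 24 h; on this read-out higher numbers stand for an effect only at larger amounts of compound and lower numbers for an effect already at smaller amounts. Compound 3 has the lowest number of the three: one step, a 4.1-fold lower number from compound 1 to compound 3 (0.61 log units; beyond the scatter), is beyond the scatter, while the other, a 1.8-fold lower number from compound 2 to compound 3 (0.26 log units; within the scatter), lies within it, so compound 3 and compound 2 cannot be ordered against each other.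

Compound 4, `CC(C)c1ccc(C(=O)NN(C(=O)c2ccccc2Cl)C(C)(C)C)cc1`, is not yet measured. Its change from compound 3 is isopropyl in place of methyl on an aromatic carbon. For the measured compounds named here, the steps that bear on this place are a 2.2-fold lower number from compound 1 to compound 2 (0.35 log units; beyond the scatter) and a 4.1-fold lower number from compound 1 to compound 3 (0.61 log units; beyond the scatter), both modest and both toward lower numbers when a group is put on that aromatic carbon; a 1.8-fold lower number from compound 2 to compound 3 (0.26 log units; within the scatter) is within the scatter. Going by the values given here, no measured step enlarges the group beyond methyl, so the size of the next step is not covered by the data. The expectation is therefore a step of a 1.9-fold higher number from compound 3 to compound 4 (0.27 log units; within the scatter) in this assay, not clearly beyond the scatter in either direction. Compound 4 is estimated at 35 nM, with a range of 10 nM to 120 nM.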

Compound 4, half-maximal effective concentration: 24.6 nM
The estimate for compound 4 lay 1.4-fold (0.15 log units) above the measured number; the measured number falls inside the stated range.
By their numbers in this assay, from the lowest: compounds 3, 4 and 2 (each within the scatter of the next); then compound 1.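

In this assay, the aromatic carbon para to a large group accepts isopropyl with no clear shift from the smaller groups: a 1.3-fold higher number from compound 3 to compound 4 (0.12 log units; within the scatter) and a 1.4-fold lower number from compound 2 to compound 4 (0.14 log units; within the scatter) both stay within the scatter. The drop from the unsubstituted ring also survives the larger group, with a 3.1-fold lower number from compound 1 to compound 4 (0.49 log units; beyond the scatter) beyond the scatter, so bromo, methyl and isopropyl all lie below hydrogen here and no compound shown goes against this. Nothing available offers a reason for this result.

Still open, going by these compounds, is how far size can grow at this carbon before the number rises, for example with tert-butyl or a longer chain. Also open, on these data alone, is whether groups carrying oxygen or nitrogen, such as methoxy, an amine or a carboxylic acid, fit the same picture.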